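From aryl to carbamoylmethyl on the ring nitrogen

A few compounds are considered here, and "the series" means these few. Any claim that something is new, unique, unknown or untested is made for them only; others in the source may bear on it.

Compound 3 `CCOC(=O)C1=Cc2ccccc2OC1(OCc1cn(-c2ccc(F)c(Cl)c2)nn1)C(F)(F)F` gives 26300 nM in a functional assay on A549 cells (Homo sapiens) for inhibition, read by MTT assay, with a stated time of 24 h (on this read-out lower numbers stand for stronger inhibition and higher numbers for weaker inhibition), the lowest of the two numbers shown. Compound 1 `CCOC(=O)C1=Cc2ccccc2OC1(OCc1cn(CC(=O)Nc2ccccc2F)nn1)C(F)(F)F` sits nearest, with 50100 nM in this assay, and the step of a 1.9-fold lower number from compound 1 to compound 3 (0.28 log units; within the scatter) lies within the scatter, so neither compound can be called more potent than the other. Compound 2 `CCOC(=O)C1=Cc2ccccc2OC1(OCc1cn(-c2ccccc2)nn1)C(F)(F)F` yields no number in this assay but only a limit, > 150000 nM. The step of an at least 5.7-fold lower number from compound 2 to compound 3 (0.75 log units; beyond the scatter) is beyond the scatter.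

Compound 4 `CCOC(=O)C1=Cc2ccccc2OC1(OCc1cn(CC(=O)Nc2cccc(Cl)c2)nn1)C(F)(F)F` is not yet measured. It differs from compound 3 in one place: ((3-chlorophenyl)carbamoyl)methyl in place of 3-chloro-4-fluorophenyl on an aromatic nitrogen. The step that bears on it most is a 1.9-fold lower number from compound 1 to compound 3 (0.28 log units; within the scatter), where compound 1 carries a ((2-fluorophenyl)carbamoyl)methyl group on the same aromatic nitrogen and compound 3 the 3-chloro-4-fluorophenyl; that difference stayed within the scatter. The step of an at least 5.7-fold lower number from compound 2 to compound 3 (0.75 log units; beyond the scatter) shows that the group on this nitrogen can matter, yet compound 4 keeps a chlorine-bearing phenyl within its new group. A step toward a higher number, near the edge of the scatter, is therefore expected, a 1.7-fold higher number from compound 3 to compound 4 (0.23 log units; within the scatter). Compound 4 is estimated at 45000 nM, with a likely range from 15000 nM to 140000 nM.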

Compound 4, half-maximal inhibitory concentration: 12800 nM
Compound 4: the middle estimate sits 3.5-fold (0.55 log units) above what was measured; the measured number lies below the stated range.
By their numbers in this assay, from the lowest: compound 4; then compounds 3 and 1 (each within the scatter of the next). At a limit, above all of these: compound 2.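

In this assay, within the data shown here, the step of a 2.1-fold lower number from compound 3 to compound 4 (0.31 log units; beyond the scatter) is the first move from an aryl group to a carbamoylmethyl group on this aromatic nitrogen that passes beyond the scatter, so an aryl group sitting directly on the nitrogen is not needed for the lowest number seen so far. The aryl end of the new group also counts, which compound 1 and compound 3 alone could not show: 3-chlorophenyl in place of 2-fluorophenyl on the amide-type nitrogen gives a 3.9-fold lower number from compound 1 to compound 4 (0.59 log units; beyond the scatter). The step of an at least 11-fold lower number from compound 2 to compound 4 (1.06 log units; beyond the scatter) is large, yet one end of it is a limit of the assay and not a number, so its true size stays unknown: the limit of > 150000 nM in this assay, at which 1 of the 4 values shown sits.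

The groups 3-chlorophenyl and 2-fluorophenyl differ in both the halogen and its place on the ring, and the compounds shown do not separate these two changes. They also leave open what a longer chain between the ring nitrogen and the carbonyl would give, or a carboxylic acid or an amine in place of the 3-chlorophenyl on the amide-type nitrogen.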